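The compounds below may be only part of what the source reports. "The series", "measured", "known", "first", "only" and "open" are said of these compounds alone.

Measured in a functional assay for inhibition, with Rattus norvegicus as the target; a higher number here means a weaker inhibitor, a lower number a stronger inhibitor:
Compound 1 `CC(/N=c1\c(O)c(O)\c1=N/c1ccc(C#N)cc1)C(C)(C)C`: 520 nM
Compound 2 `CC(C)(C)/N=c1\c(O)c(O)\c1=N/c1ccc(C#N)cc1`: 560 nM
Compound 3 `CC(C)/N=c1\c(O)c(O)\c1=N/c1ccc(C#N)cc1`: 13700 nM

Compound 3 has the highest number of the three and is the weakest inhibitor measured so far in this assay. The next compound, compound 4 `CCCCCCC/N=c1\c(O)c(O)\c1=N/c1ccc(C#N)cc1`, carries heptyl in place of isopropyl on a double-bonded nitrogen.

For the measured compounds named here, no measured step involves heptyl, so the available steps bear on this change only indirectly. Both a 24-fold higher number from compound 2 to compound 3 (1.39 log units; beyond the scatter) and a 26-fold higher number from compound 1 to compound 3 (1.42 log units; beyond the scatter) are large, and they show isopropyl at the weak end of the series. Larger alkyl groups do not always lower the number further, since a 1.1-fold higher number from compound 1 to compound 2 (0.03 log units; within the scatter) stays within the scatter. The data do not show whether an unbranched chain behaves like the groups of compound 1 and compound 2. A lower number is therefore expected, but by a smaller step than those large ones. The estimate amounts to an expected 4.6-fold lower number from compound 3 to compound 4 (0.66 log units; beyond the scatter). Compound 4 is expected at 3000 nM, with an estimated range of 600 nM to 15000 nM.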

Compound 4, half-maximal inhibitory concentration: > 30000 nM
Compound 4: a limit, no number; the forecaster's own chance of this, stated with the estimate: 3%; at least 10-fold (1.00 log units) between middle value and limit.
By their numbers in this assay, from the lowest: compounds 1 and 2 (each within the scatter of the next); then compound 3. At a limit, above all of these: compound 4.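

On a double-bonded nitrogen, a larger alkyl group does not by itself give a lower number in this assay: heptyl in place of isopropyl gives an at least 2.1-fold higher number from compound 3 to compound 4 (0.34 log units; beyond the scatter) and so runs against the order of compound 1 and compound 2 over compound 3. Against the branched groups the gap is wider, with heptyl giving an at least 53-fold higher number from compound 2 to compound 4 (1.72 log units; beyond the scatter) and an at least 57-fold higher number from compound 1 to compound 4 (1.76 log units; beyond the scatter) in the same assay. The value of compound 4 is > 30000 nM and is a limit of the assay, not a number: the limit of > 30000 nM in this assay, at which 1 of the 4 values shown sits.

As far as these compounds go, whether chain length or the absence of branching separates compound 4 from compound 1 and compound 2 remains open. A butyl chain or a cyclohexyl group at this place could be informative, as neither is among the compounds shown.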